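Replacing the trifluoromethylphenoxy arm with phenyl

The source may hold more compounds than are shown below. What is called first, only, known or untested is meant among the compounds shown, and "the series" means these compounds.

Of the compounds shown here, two have so far been tested in an ADME assay on S9 fraction from liver (Rattus norvegicus) for metabolic stability, read by LC-MS, using NADPH, with a stated time of 30 min; on this read-out higher numbers stand for a more stable compound and lower numbers for a less stable compound. Compound 1 `CC(Oc1ccc(Oc2ccc(Cl)cc2)cc1)C(=O)Cn1nnc(-c2ccccc2)n1` sits at < 5%, which is a limit of the assay and not a number. Compound 2 `CC(Oc1ccc(Oc2ccc(C(F)(F)F)cc2)cc1)C(=O)Cn1nnc(-c2ccccc2)n1` gives 6%. The step of a number at least 1 percentage points higher from compound 1 to compound 2 (that floor lies within the scatter) rests on a floor, since compound 1 sits at the limit of < 5% in this assay, at which 1 of the 2 values shown sits. Compound 2 therefore holds the only actual number shown, while the one other value is a limit. Compound 3 `CC(Oc1ccc(-c2ccccc2)cc1)C(=O)Cn1nnc(-c2ccccc2)n1` differs from compound 2 by phenyl in place of 4-(trifluoromethyl)phenoxy on an aromatic carbon. Among the measured compounds shown here, only the step of a number at least 1 percentage points higher from compound 1 to compound 2 (that floor lies within the scatter) bears on this change, and it was a small rise whose floor lies within the scatter; both measured compounds sit near the low end. That change was of a different kind, so it offers little guidance beyond placing the series low. Compound 3 is expected to remain low, with an expected step of a number 2 percentage points higher from compound 2 to compound 3 (within the scatter). The estimated value for compound 3 is 8%, ranging from 1% to 25%.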

Compound 3, percent of the compound remaining: < 5%
Compound 3 ended at the assay's limit (the forecaster's own chance of this, stated with the estimate: 35%); middle value at least 3 percentage points away from the limit.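

In this assay, phenyl in place of 4-(trifluoromethyl)phenoxy gives a number at least 1 percentage points lower from compound 2 to compound 3 (that floor lies within the scatter). Compound 3 sits at < 5%, which is a limit of the assay and not a number. The step between compound 1 and compound 3 cannot be read, and the change to phenyl on this aromatic carbon leaves the series at the low end, where the two phenoxy arms also sit: the limit of < 5% in this assay, at which 2 of the 3 values shown sit.

The compounds shown leave open whether any other group on this aromatic carbon, such as an amine or a carboxylic acid, would lift the read-out clear of the limit in this assay. They also leave open whether the low values depend on this arm at all or on another part of the shared core, such as the carbonyl.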